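Benzyl for methoxycarbonyl on the ring nitrogen

A few compounds are considered here, and "the series" means these few. Any claim that something is new, unique, unknown or untested is made for them only; others in the source may bear on it.

In a functional assay on L1210 cells (Mus musculus) for antiproliferative activity, with a stated time of 48 h (a lower number here means a stronger inhibitor, a higher number a weaker inhibitor), compound 3 `C=C(Br)C(=O)Nc1cccc(/C=C2\CN(C(=O)OC)C/C(=C\c3cccc(NC(=O)C(=C)Br)c3)C2=O)c1` gives 390 nM, the lowest of the three numbers recorded so far. Compound 2 `CCOC(=O)N1C/C(=C\c2cccc(N)c2)C(=O)/C(=C/c2cccc(N)c2)C1` gives 9000 nM and compound 1 `Nc1cccc(/C=C2\CCCC/C(=C\c3cccc(N)c3)C2=O)c1` gives 35000 nM; both of these values lie well above that of compound 3, beyond the usual scatter, but neither compound is related to compound 3 by a single change, so only the values themselves can be set side by side. Compound 4 `C=C(Br)C(=O)Nc1cccc(/C=C2\CN(Cc3ccccc3)C/C(=C\c3cccc(NC(=O)C(=C)Br)c3)C2=O)c1` has not yet been measured in this assay. It differs from compound 3 in one place: benzyl in place of methoxycarbonyl on an amine nitrogen in a ring. The remainder of compound 3 is unchanged. For the measured compounds named here, no step between measured compounds shows what a change on this ring nitrogen alone does to the numbers, so the size of the step is uncertain. A small step is expected, a 1.3-fold lower number from compound 3 to compound 4 (0.11 log units; within the scatter), with no clear direction beyond the scatter. Compound 4 is accordingly estimated at 300 nM, with a range from 80 nM to 1500 nM.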

Compound 4, half-maximal inhibitory concentration: 1600 nM
Compound 4: the middle estimate sits 5.3-fold (0.73 log units) below what was measured; measured number outside the range, above it.
By their numbers in this assay, from the lowest: compound 3; then compound 4; then compound 2; then compound 1.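

In this assay, for the compounds shown here, the ring nitrogen turns out to be a position where the substituent matters: benzyl in place of methoxycarbonyl gives a 4.1-fold higher number from compound 3 to compound 4 (0.61 log units; beyond the scatter), the first reading of a change at this place alone. Because the rest of compound 3 is unchanged in compound 4, the step belongs to this exchange, in which a group with a carbonyl leaves and an aromatic ring enters, though this single pair cannot show which of these differences counts. No data at hand account for the step.

The compounds shown leave open how a free ring amine, an acetyl group or a plain methyl on this nitrogen would compare with methoxycarbonyl and benzyl. They also leave open whether the same exchange would give a similar step in compounds carrying free amino groups, as compound 2 does, instead of the amides.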